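Thioester chain lengthening across two heteroaryl cores

The source may report more compounds than this note shows. Statements on the series, on what has been measured and on what is new or still open speak of the compounds shown alone.

Working notes on the series. Compound 1 `CCSC(=O)C1=C(C)NC(=O)NC1c1ccoc1` is the parent of the set, and in an assay on membranes from CHO cells for displacement of a labelled ligand from adenosine receptor A1 (Homo sapiens), read by scintillation counting, with a stated time of 60 min, tested at 1 uM (a higher number here means more inhibition at the concentration tested (going by the name of the read-out), a lower number less inhibition), compound 1 gives 3%. Compound 2 `CC1=C(C(=O)SC(C)C)C(c2ccoc2)NC(=O)N1` carries the change (methyl in place of hydrogen on a saturated chain carbon bound to a saturated chain carbon and a sulfur), and in this assay compound 2 gives 9%. The step of a number 6 percentage points higher from compound 1 to compound 2 (within the scatter) is small. Compound 3 `CCSC(=O)C1=C(C)NC(=O)NC1c1cccs1` differs from compound 1 only in the core, through (thiophen-2-yl in place of furan-3-yl on a saturated ring carbon), and in this assay compound 3 gives 6%. The step of a number 3 percentage points higher from compound 1 to compound 3 (within the scatter) does not separate the two cores.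

Compound 4 `CC1=C(C(=O)SC(C)C)C(c2cccs2)NC(=O)N1` is not yet measured. It stands to compound 3 as compound 2 stands to compound 1, through (methyl in place of hydrogen on a saturated chain carbon bound to a saturated chain carbon and a sulfur), a change made at the identical place in both pairs and occurring twice in the set, so the same change is read across two cores that the measured data do not tell apart.

Grounds for the expectation: the one measured instance of this change, a number 6 percentage points higher from compound 1 to compound 2 (within the scatter), stayed within the scatter, and compound 3 with 6% sits where compound 1 sits within the scatter. For compound 4 a step of a number 3 percentage points higher from compound 3 to compound 4 (within the scatter) is expected, of the same small size as the earlier one, resting on that single measured pair. In this assay compound 4 is expected to give about 9%, with an estimated range from 0% to 20%.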

Compound 4, a percentage reported as inhibition, at one concentration (the size of the read-out at that concentration, not a potency): 1%
Compound 4: the middle estimate sits 8 percentage points above what was measured; measured number inside the range.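

In this assay, the change from ethylsulfanyl to isopropylsulfanyl gives a number 5 percentage points lower from compound 3 to compound 4 (within the scatter), and this step does not differ from its counterpart on the other core: the same change on two cores in this assay, a number 6 percentage points higher (within the scatter) from compound 1 to compound 2 and a number 5 percentage points lower (within the scatter) from compound 3 to compound 4, 11 percentage points apart, within the scatter of two such steps The exchange of furan-3-yl for thiophen-2-yl on the isopropyl compounds gives a number 8 percentage points lower from compound 2 to compound 4 (within the scatter), and it likewise agrees with the same exchange on the ethyl compounds: the same change on two cores in this assay, a number 3 percentage points higher (within the scatter) from compound 1 to compound 3 and a number 8 percentage points lower (within the scatter) from compound 2 to compound 4, 11 percentage points apart, within the scatter of two such steps This gives no sign that the methyl change depends on the core, but it does not show that an effect carries from one core to the other; every step in the set lies within the scatter, so no effect of the change has been resolved on either core.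

Going by these compounds, it remains open whether a longer chain or a benzyl group on the thioester sulfur, or a phenyl group in place of furan-3-yl and thiophen-2-yl, would move the number in this assay clear of the scatter. Also open, on these data alone, is whether an oxygen ester in place of the thioester would behave any differently, and whether a methyl change would then carry from one core to another.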